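From 2-Methylbenzyl to 2,6-Difluorobenzyl on Sulfur

The source may hold more compounds than are shown below. What is called first, only, known or untested is meant among the compounds shown, and "the series" means these compounds.

In a functional assay on HeLa cells (Homo sapiens) for antiproliferative activity, read by MTT assay, with a stated time of 24 h (on this read-out lower numbers stand for stronger inhibition and higher numbers for weaker inhibition), compound 1 (`Sc1nnc(-c2ccc3c(c2)OCCO3)n1-c1ccccc1`) gives 51900 nM, and compound 2 (`Cc1ccccc1CSc1nnc(-c2ccc3c(c2)OCCO3)n1-c1ccccc1`) gives 36000 nM. With only these two numbers available, compound 2 cannot be told apart from compound 1. Compound 3 (`Fc1cccc(F)c1CSc1nnc(-c2ccc3c(c2)OCCO3)n1-c1ccccc1`) carries 2,6-difluorophenyl in place of 2-methylphenyl on a saturated chain carbon bound to a sulfur. Going by the values given here, no measured step makes this exchange directly. Among the compounds with values here, the only related evidence is the one that put 2-methylbenzyl in place of hydrogen on the sulfur, a 1.4-fold lower number from compound 1 to compound 2 (0.16 log units; within the scatter). Since even that addition stayed small, no step beyond the scatter is expected in this assay, and no direction can be favoured. The expected step is a 1.1-fold lower number from compound 2 to compound 3 (0.04 log units; within the scatter). Compound 3 is estimated at 33000 nM, with an expected range of 14000 nM to 75000 nM.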

Compound 3, half-maximal inhibitory concentration: 35200 nM
Estimate against measurement, compound 3: 1.1-fold (0.03 log units) below; the range from low to high includes it.
By their numbers in this assay, from the lowest: compounds 3, 2 and 1 (each within the scatter of the next).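

In this assay, going from 2-methylbenzyl to 2,6-difluorobenzyl on the sulfur gives a 1.0-fold lower number from compound 2 to compound 3 (0.01 log units; within the scatter) and so leaves the number essentially where it was, even though the methyl is gone and two fluorines have entered. Going by these compounds alone, measured against hydrogen on the sulfur, 2,6-difluorobenzyl gives a 1.5-fold lower number from compound 1 to compound 3 (0.17 log units; within the scatter) and so, like 2-methylbenzyl, stays within the scatter, which means that a second, differently substituted benzyl group at this sulfur separates no compound from the others. No evidence is available that bears on why these numbers lie so close together.

Going by these compounds, it remains open whether a group of another kind on the sulfur, such as a longer chain ending in an amine or a carboxylic acid, would move the number beyond the scatter. Also open, on these data alone, is whether a benzyl group carrying a nitro or methoxy group would stay as close.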